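Exchanging the methylpyrazole for a cyanopyridine

The source may hold more compounds than are shown below. What is called first, only, known or untested is meant among the compounds shown, and "the series" means these compounds.

Compound 1 `Cn1cc(-c2cc(Cl)c3ncc(Cc4ccc5ncccc5c4)n3c2)cn1`, compound 2 `Cn1cc(-c2cc(C(F)(F)F)c3ncc(Cc4ccc5ncccc5c4)n3c2)cn1` and compound 3 `Cn1cc(-c2cc(F)c3ncc(Cc4ccc5ncccc5c4)n3c2)cn1` carry the same 1-methyl-1H-pyrazol-4-yl group on closely related cores. In a functional assay on EBC-1 cells (Homo sapiens) for antiproliferative activity, with a stated time of 72 h (a lower number here means a stronger inhibitor, a higher number a weaker inhibitor), compound 1 gives "not determined" (no result reported), and compound 2 likewise gives "not determined" (no result reported). For the measured compounds named here, compound 3 gives 0.27 nM, the only number available, so it cannot be ranked against anything. Compound 4 `N#Cc1ccc(-c2cc(F)c3ncc(Cc4ccc5ncccc5c4)n3c2)cn1` has 6-cyanopyridin-3-yl in place of that group, on an aromatic carbon meta to a fluoro group: 6-cyanopyridin-3-yl in place of 1-methyl-1H-pyrazol-4-yl on an aromatic carbon. Going by the values given here, no measured pair tests such an exchange, so the expectation is loose. With compound 3 already at 0.27 nM, a loss in this assay seems the likelier direction. The expected change is a 3.7-fold higher number from compound 3 to compound 4 (0.57 log units; beyond the scatter), towards weaker inhibition and probably beyond the scatter. For compound 4 the estimated value is 1 nM, with an expected range of 0.2 nM to 6 nM.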

Compound 4, half-maximal inhibitory concentration: 189 nM
The estimate for compound 4 lay 190-fold (2.28 log units) below the measured number; the whole stated range lies below it.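

In this assay, for the compounds shown here, putting 6-cyanopyridin-3-yl in place of 1-methyl-1H-pyrazol-4-yl gives a 700-fold higher number from compound 3 to compound 4 (2.85 log units; beyond the scatter), the first readable step at this position. On this core, then, the position does not treat the two aromatic groups alike, even though both count the same hydrogen-bond acceptors and neither has a donor. Nothing available explains the loss.

On these data alone, whether it follows from the six-membered ring or from the nitrile stays open. A plain pyridin-3-yl or a 6-aminopyridin-3-yl at this position would separate those two readings.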